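The compounds below may be only part of what the source reports. "The series", "measured", "known", "first", "only" and "open" are said of these compounds alone.

Compound 3 `C=CCn1ncc2c(C)nc(C(C)C)n2c1=O` sits at the weak end of what is shown. In a functional assay for inhibition, with Homo sapiens as the target (a lower number here means a stronger inhibitor, a higher number a weaker inhibitor), compound 3 gives > 48000 nM, which is a limit of the measurement rather than a number. The same is true of compound 1 `CCCc1nc(C)c2cnn(CC3CC3)c(=O)n12`: in this assay compound 1 gives > 48000 nM, again only a limit. Going by the values given here, the one numerical value in the set belongs to compound 2 `CC(C)CCSc1nncc2cncn12`, which in this assay gives 9000 nM. Two of the three values thus rest at the limit of > 48000 nM in this assay, at which 2 of the 3 values shown sit.

Compound 4 `C=CCn1ncc2c(C)nc(CCC)n2c1=O` has not yet been measured. It differs from compound 3 by propyl in place of isopropyl on an aromatic carbon, so the two share every atom and differ only in how the three-carbon chain is branched. Among the compounds with values here, no measured pair in this set differs in a single place, so the size of such a step cannot be read from the data. Within the data shown here, compound 1 carries the same propyl group and also reaches only the limit in this assay, while the one compound with a number, compound 2, is built on a different core. Compound 4 is therefore expected to lie at or beyond the limit as well, with the step from a step that the limit leaves unreadable from compound 3 to compound 4 estimated to be no larger than the usual scatter. The estimate for compound 4 in this assay is 60000 nM, within a range of 20000 nM to 200000 nM.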

Compound 4, half-maximal inhibitory concentration: 40000 nM
Beside the measured number, compound 4's estimate is 1.5-fold (0.18 log units) above it; the measured number falls inside the stated range.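

Going by these compounds alone, compound 4 is the first compound on the shared core to give a number rather than a limit in this assay, which puts a floor on the change at this aromatic carbon for the first time. Propyl in place of isopropyl gives an at least 1.2-fold lower number from compound 3 to compound 4 (0.07 log units; that floor lies within the scatter), and vinyl in place of cyclopropyl on the saturated chain carbon bound to an aromatic nitrogen gives an at least 1.2-fold lower number from compound 1 to compound 4 (0.07 log units; that floor lies within the scatter). Neither change can be shown to exceed the scatter, and the full size of each step stays unread, since one end of both pairs rests on a limit: the limit of > 48000 nM in this assay, at which 2 of the 4 values shown sit.

The compounds shown leave open how a longer chain, a phenyl ring or an amine would read on this aromatic carbon of the shared core, as only three-carbon chains appear there apart from the different group on compound 2's own core. Compound 2, at 9000 nM, differs from the others in more than one place, so what separates its number from theirs remains unresolved.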